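Second chloro on the fused core, two benzyl isomers

The compounds below may be only part of what the source reports. "The series", "measured", "known", "first", "only" and "open" are said of these compounds alone.

Compound 1 `ClCc1cccc(Cn2cnc3c(Cl)ncnc32)c1` gives 6310 nM in a functional assay on UACC-62 cells (Homo sapiens) for cytotoxicity, read by sulforhodamine B assay, with a stated time of 48 h; a lower number here means that less compound is tolerated, a higher number that more compound is tolerated. Compound 2 `ClCc1cccc(Cn2cnc3c(Cl)nc(Cl)nc32)c1` gives 6450 nM in this assay. The change from compound 1 to compound 2 is chloro in place of hydrogen on an aromatic carbon and it gave a 1.0-fold higher number from compound 1 to compound 2 (0.01 log units; within the scatter). Compound 3 `ClCc1ccccc1Cn1cnc2ncnc(Cl)c21` gives 19100 nM in this assay, the highest of the three numbers; how its core differs from the core of compound 1 is not broken down here. Compound 4 `ClCc1ccccc1Cn1cnc2nc(Cl)nc(Cl)c21` is not yet measured in this assay. Its difference from compound 3 is chloro in place of hydrogen on an aromatic carbon, the same change as from compound 1 to compound 2, at a place described in the same words. The step from compound 3 to compound 4 is expected to be a 1.0-fold higher number from compound 3 to compound 4 (0.01 log units; within the scatter), set beside a 1.0-fold higher number from compound 1 to compound 2 (0.01 log units; within the scatter), the effect of the same change in the measured pair. Compound 4 is estimated at 19500 nM, in a range from 9000 nM to 42000 nM.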

Compound 4, concentration lethal to 50% of the cells: 6760 nM
The estimate for compound 4 lay 2.9-fold (0.46 log units) above the measured number, and the stated range ends above it.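

Chloro in place of hydrogen on an aromatic carbon gave a 2.8-fold lower number from compound 3 to compound 4 (0.45 log units; beyond the scatter) in this assay, so the effect of this change did not carry over unaltered from one core to the other: the same change on two cores in this assay, a 1.0-fold higher number (0.01 log units; within the scatter) from compound 1 to compound 2 and a 2.8-fold lower number (0.45 log units; beyond the scatter) from compound 3 to compound 4, 2.9-fold (0.46 log units) apart, beyond the scatter of two such steps

With one pair on each core, this shows that the step cannot be assumed to transfer within the series. It does not show which structural difference between the two cores accounts for the gap, or how the change would behave on any other core.

Open, going by these compounds, is whether an amine or a methoxy group on the same carbon, between two ring nitrogen atoms, would differ between the two cores as chloro does. Also open, on these data alone, is how a longer chain in place of the chloromethyl group would affect either core.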